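The source may report more compounds than this note shows. Statements on the series, on what has been measured and on what is new or still open speak of the compounds shown alone.

Measured so far in a functional assay on SNU-638 cells (Homo sapiens) for cytotoxicity, read by sulforhodamine B assay, with a stated time of 72 h; a lower number here means a stronger inhibitor, a higher number a weaker inhibitor:
compound 1 `CCS(=O)(=O)Nc1cc(-c2ccc3ncnc(Nc4ccc(F)cc4)c3c2)cnc1OC` gives 2400 nM
compound 2 `CCS(=O)(=O)Nc1cc(-c2ccc3ncnc(Nc4cccc(C(=O)OC)c4)c3c2)cnc1OC` gives 1120 nM

Within the data shown here, of these two numbers, compound 2 holds the lower one, and the only measured step, a 2.1-fold lower number from compound 1 to compound 2 (0.33 log units; beyond the scatter), lies beyond the usual scatter. Compound 3 `CCS(=O)(=O)Nc1cc(-c2ccc3ncnc(Nc4ccc(C(=O)OC)c(OC)c4)c3c2)cnc1OC` has not yet been measured in this assay. Relative to compound 2, the change is 3-methoxy-4-(methoxycarbonyl)phenyl in place of 3-(methoxycarbonyl)phenyl on a nitrogen on an aromatic ring. Among the measured compounds shown here, no measured step matches this change: the step from compound 1 to compound 2 exchanged one group on that nitrogen for an entirely different one and was modest, but it says nothing about the present exchange, which keeps the methoxycarbonyl group and adds a methoxy group. With no guide in the numbers, compound 3 is expected to change little, with an estimated step of a 1.0-fold lower number from compound 2 to compound 3 (0.01 log units; within the scatter) that would not count as a change beyond the scatter. The estimate for compound 3 in this assay is 1100 nM, within a range from 400 nM to 3200 nM.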

Compound 3, half-maximal inhibitory concentration: 3440 nM
The estimate for compound 3 lay 3.1-fold (0.50 log units) below the measured number; the whole stated range lies below it.
By their numbers in this assay, from the lowest: compound 2; then compounds 1 and 3 (each within the scatter of the next).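

In this assay the group on this nitrogen proves sensitive to its exact substitution: going to 3-methoxy-4-(methoxycarbonyl)phenyl brings a 3.1-fold higher number from compound 2 to compound 3 (0.49 log units; beyond the scatter) and so shows that carrying a methoxycarbonyl group does not by itself secure the lower number. Against the 4-fluorophenyl group, the new group gives a 1.4-fold higher number from compound 1 to compound 3 (0.16 log units; within the scatter) and thus no clear difference, so the advantage of compound 2 belongs to its own 3-(methoxycarbonyl)phenyl group, not to every phenyl group bearing methoxycarbonyl. No measurement at hand explains this loss.

The names show that the methoxycarbonyl group is numbered 3 in one compound and 4 in the other, while a methoxy group also enters, and the compounds shown do not separate these two changes. Also open, as far as these compounds go, is how this assay would respond to a carboxylic acid or an amide in place of the methoxycarbonyl group.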